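Swapping the acyl hydrazone of compound 1 for an aminoguanidine

A few compounds are considered here, and "the series" means these few. Any claim that something is new, unique, unknown or untested is made for them only; others in the source may bear on it.

The starting point is compound 1, `O=C(/C=C/c1ccc(/C=N/NC(=O)c2ccncc2)cc1)c1cccc(Br)c1`, which in a functional assay on the whole organism (Ear) for inhibition, with Mus musculus as the target, with a stated time of 30 min, at a dose of 100 mg/kg by the intraperitoneal route (a lower number here means less inhibition, a higher number more inhibition at the dose given (going by the name of the read-out)), gives 14%. Among the measured compounds shown here, only one other compound has a number here: compound 2, `Cc1ccc(C(=O)/C=C/c2ccc(/C=N/NC(=O)c3ccccc3)cc2)c(C)c1`, which in this assay gives 0.18%. On these two numbers compound 1 stands highest, and the gap to compound 2 is beyond the usual scatter of the measurement. For the measured compounds named here, the two compounds differ in more than one place, so no single step between them can be read off, and nothing is yet known about how the hydrazone end of the molecule affects the read-out on its own.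

The next compound to be measured is compound 3, `N=C(N)N/N=C/c1ccc(/C=C/C(=O)c2cccc(Br)c2)cc1`. It keeps the core of compound 1 and changes one group: a group of 3 heavy atoms (1 carbon, 2 nitrogen; no ring) in place of a group of 8 heavy atoms (6 carbon, 1 nitrogen, 1 oxygen; one six-membered aromatic ring with 1 hetero atom), on an amine nitrogen. Going by the values given here, with no measured step of this kind to guide the expectation, the step from compound 1 to compound 3 is expected to be a number 4 percentage points lower from compound 1 to compound 3 (within the scatter), that is, small and most likely within the scatter. In this assay compound 3 is accordingly expected to give about 10%, with a plausible range from 0% to 35%.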

Compound 3, a percentage reported as inhibition, in the whole organism at one dose (the size of the read-out at that dose, not a potency): 49.7%
Beside the measured number, compound 3's estimate is 39.7 percentage points below it, and the stated range ends below it.
By their numbers in this assay, from the lowest: compound 2; then compound 1; then compound 3.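

Among the compounds shown here, the change gives the first single-place step in this assay: on the amine nitrogen whose other neighbour is a double-bonded nitrogen, putting the group of 3 heavy atoms in place of (pyridin-4-yl)carbonyl gives a number 35.7 percentage points higher from compound 1 to compound 3 (beyond the scatter), a large step. The read-out therefore responds strongly to what sits at this position while the rest of the molecule stays the same, and the six-membered aromatic ring and the carbonyl of the leaving group are not required for inhibition at the dose given. Nothing available bears on why the number moves this far.

The compounds shown leave open whether the step comes from losing the (pyridin-4-yl)carbonyl group or from what enters, since both happen in one change; a urea or a plain acetyl group on the same nitrogen would begin to separate the two. From the compounds shown here alone, it also remains open whether the same replacement would give a step of similar size on the core of compound 2, or with a group other than the bromine-bearing ring at the far end of compound 3.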